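Dropping the whole acyl group from an amide nitrogen

The source may report more compounds than this note shows. Statements on the series, on what has been measured and on what is new or still open speak of the compounds shown alone.

Measured so far:
compound 1 `COc1cc(/C=C/C(=O)c2cccc(NC(=O)c3c(Cl)cccc3Cl)c2)ccc1O` gives 99%
compound 2 `COc1cc(/C=C/C(=O)c2cccc(NC(=O)c3cccs3)c2)ccc1O` gives 90%

Both were tested in a functional assay on HUVEC cells (Homo sapiens) for inhibition, tested at 10 ug/mL; a higher number here means a stronger effect of the compound at the concentration tested, a lower number a weaker effect. Compound 1 holds the highest of the two numbers, and its nearest neighbour is compound 2; the step of a number 9 percentage points lower from compound 1 to compound 2 (within the scatter) shows that thiophen-2-yl in place of 2,6-dichlorophenyl on a carbonyl carbon leaves the read-out within the scatter.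

Compound 3 `COc1cc(/C=C/C(=O)c2cccc(N)c2)ccc1O` has not yet been tested. It differs from compound 1 by hydrogen in place of (2,6-dichlorophenyl)carbonyl on a nitrogen on an aromatic ring. Within the data shown here, no measured step removes the carbonyl-bearing group from that nitrogen; the single step seen only exchanges one ring for another on the carbonyl, so it gives no direct guide to what a bare nitrogen does. The estimate for compound 3 therefore carries a wide range: it is expected to give 75%, between 40% and 99%, in this assay. The step from compound 1 is expected to be a number 24 percentage points lower from compound 1 to compound 3 (beyond the scatter), a drop somewhat beyond the scatter.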

Compound 3, a percentage reported as inhibition, at one concentration (the size of the read-out at that concentration, not a potency): 90%
For compound 3 the middle estimate is 15 percentage points below the measured one; low and high end bracket the measured number.
By their numbers in this assay, from the lowest: compounds 2, 3 and 1 (each within the scatter of the next).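

With this assay as the test, hydrogen in place of (2,6-dichlorophenyl)carbonyl on the nitrogen gives a number 9 percentage points lower from compound 1 to compound 3 (within the scatter) and hydrogen in place of (thiophen-2-yl)carbonyl gives no change at the digits printed from compound 2 to compound 3 (within the scatter) and so, across these three compounds, the read-out at this one concentration does not depend on an acyl group being on this nitrogen. Among these compounds, the earlier pair showed only that one ring could replace another on the carbonyl, whereas these steps show that the carbonyl and its ring can go altogether without a change beyond the scatter. Nothing available here explains this result.

Going by these compounds, what a methyl or acetyl group on this nitrogen would do remains open, as does a carboxylic acid in place of the amine. On these data alone, whether the three compounds would separate at lower concentrations also remains open.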